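The source may report more compounds than this note shows. Statements on the series, on what has been measured and on what is new or still open speak of the compounds shown alone.

Compound 1 `CN1CCN(c2ccc3[nH]nc(S(=O)(=O)c4ccccc4Cl)c3c2)CC1`: 100%
Compound 2 `CN1CCN(c2ccc3[nH]nc(S(=O)(=O)c4ccc(F)cc4)c3c2)CC1`: 98%

In a functional assay on HeLa cells for antagonist activity at 5-hydroxytryptamine receptor 6 (Homo sapiens) (a lower number here means a smaller maximal response, a higher number a larger maximal response), compound 1 reaches 100%. In this assay compound 2 reaches 98%. On the numbers shown, compound 2 stands level with compound 1: the gap between the two lies within the scatter. Compound 3 `CN1CCN(c2ccc3[nH]nc(S(=O)(=O)c4ccc(Cl)cc4)c3c2)CC1` differs from compound 2 by chloro in place of fluoro on an aromatic carbon. Going by the values given here, the only measured step bearing on this change is a number 2 percentage points lower from compound 1 to compound 2 (within the scatter), which stayed within the scatter. Because that step showed a number 2 percentage points lower from compound 1 to compound 2 (within the scatter), no step beyond the scatter is expected in this assay. Compound 3 is therefore estimated at 98%, within 88% to 104%, an expected step of no change at the digits printed from compound 2 to compound 3 (within the scatter).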

Compound 3, largest response reached (reported as Imax), in percent of the reference or control that the assay uses: 100%
Compound 3: the middle estimate sits 2 percentage points below what was measured; the range from low to high includes it.
By their numbers in this assay, from the lowest: compounds 2, 1 and 3 (each within the scatter of the next).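

With chloro in place of fluoro on the aromatic carbon para to a large group, this assay shows a number 2 percentage points higher from compound 2 to compound 3 (within the scatter) and, with 4-chlorophenyl in place of 2-chlorophenyl on the sulfonyl sulfur, it shows no change at the digits printed from compound 1 to compound 3 (within the scatter). Across these compounds, then, neither swapping this halogen nor shifting chloro between these two ring places separates the maximal responses. Nothing available offers an explanation for this.

Still open, going by these compounds, is whether a group other than a halogen at this para place, such as a methoxy group or an amine, would move the response beyond the scatter.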